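A few compounds are considered here, and "the series" means these few. Any claim that something is new, unique, unknown or untested is made for them only; others in the source may bear on it.

Measured in a functional assay on CHO cells for antagonist activity at adenosine receptor A1 (Homo sapiens), read by scintillation counting and cAMP accumulation; a higher number here means a weaker inhibitor, a lower number a stronger inhibitor:
compound 1 `Nc1nc(CCCc2ccccc2)nc2cn(-c3ccccc3)nc12`: 43 nM
compound 2 `COc1cccc(CCCc2nc(N)c3nn(-c4ccccc4)cc3n2)c1`: 2.41 nM

Compound 2 stands at the lowest of the two numbers in this assay; compound 1 stands nearest, and the step between them is an 18-fold lower number from compound 1 to compound 2 (1.25 log units; beyond the scatter). Compound 3 `Nc1nc(CCCc2ccccc2O)nc2cn(-c3ccccc3)nc12` carries 2-hydroxyphenyl in place of 3-methoxyphenyl on a saturated chain carbon, three bonds along the chain from an aromatic carbon. Among the measured compounds shown here, the only measured step that bears on this change is an 18-fold lower number from compound 1 to compound 2 (1.25 log units; beyond the scatter), which followed the arrival of the methoxy group; here that group leaves and a hydroxyl enters instead, so part of that step is expected to be given back. For compound 3 the expected step is an 8.3-fold higher number from compound 2 to compound 3 (0.92 log units; beyond the scatter), and the estimate is 20 nM, within 5 nM to 80 nM.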

Compound 3, half-maximal inhibitory concentration: 4.26 nM
Compound 3: middle estimate off by 4.7-fold (0.67 log units), on the high side; the measured number lies below the stated range.
By their numbers in this assay, from the lowest: compounds 2 and 3 (each within the scatter of the next); then compound 1.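

In this assay the swap of 3-methoxyphenyl for 2-hydroxyphenyl gives a 1.8-fold higher number from compound 2 to compound 3 (0.25 log units; within the scatter) and costs nothing beyond the scatter, so the gain at this chain end is not confined to the methoxy group. The added hydroxy group gives a 10-fold lower number from compound 1 to compound 3 (1.00 log units; beyond the scatter) and also clears the scatter, as the methoxy step did. Nothing on hand accounts for either gain.

Group and ring placement change together here; 2-methoxyphenyl and 3-hydroxyphenyl would separate them. Going by these compounds, whether an amine or a chlorine on the ring serves equally stays open.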